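The source may report more compounds than this note shows. Statements on the series, on what has been measured and on what is new or still open speak of the compounds shown alone.

Measured so far:
compound 1, `O=C(Nc1ccccc1)c1ccc(-c2ncccc2C(F)(F)F)cc1`, "not determined" (no result reported) in a functional assay for antagonist activity at transient receptor potential cation channel subfamily V member 1 (Rattus norvegicus); on this read-out higher numbers stand for weaker inhibition and lower numbers for stronger inhibition
compound 2, `CCCOc1cccnc1-c1ccc(C(=O)Nc2ccc(C(C)(C)C)cc2)cc1`, 20 nM

In this assay, among the compounds with values here, compound 2 holds the only number there is; compound 1 was not measured. Compound 3, `CC(C)(C)c1ccc(NC(=O)c2ccc(-c3ncccc3-c3ncc[nH]3)cc2)cc1`, differs from compound 2 by one change, (1H-imidazol-2-yl in place of propoxy on an aromatic carbon). Within the data shown here, no step between two measured compounds is available, so nothing here shows how such a swap shifts the read-out. The change is sizeable, and a loss of inhibition beyond the usual scatter is expected, a 6.0-fold higher number from compound 2 to compound 3 (0.78 log units; beyond the scatter). For compound 3 the estimate is 120 nM, within a range from 25 nM to 600 nM.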

Compound 3, half-maximal inhibitory concentration: 694 nM
For compound 3 the middle estimate is 5.8-fold (0.76 log units) below the measured one; measured number outside the range, above it.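

In this assay, putting 1H-imidazol-2-yl in place of propoxy gives a 35-fold higher number from compound 2 to compound 3 (1.54 log units; beyond the scatter), so inhibition at this carbon, ortho to a large group, clearly depends on the group it carries. The entering group brings a five-membered aromatic ring and a hydrogen-bond donor, neither of which propoxy has, and this single step cannot separate the two. No measured evidence here explains the weaker inhibition. Going by these compounds, it remains open whether a hydroxyl, an amine or a longer chain such as butoxy would keep inhibition nearer to that of compound 2.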